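A Phenyl Ring in Place of Thiophen-3-yl

The compounds below may be only part of what the source reports. "The series", "measured", "known", "first", "only" and "open" are said of these compounds alone.

Compound 1 `COc1ncnc2c1c(-c1ccsc1)cn2[C@@H]1O[C@H](CO)[C@@H](O)[C@H]1O` is the only one of the three measured compounds to give a number in a functional assay on A549 cells (Homo sapiens), read by MTT assay, with a stated time of 72 h; a lower number here means a stronger inhibitor, a higher number a weaker inhibitor; there compound 1 gives 5170 nM. Compound 2 `CN(C)c1ncnc2c1c(-c1ccsc1)cn2[C@@H]1O[C@H](CO)[C@@H](O)[C@H]1O` carries dimethylamino in place of methoxy on an aromatic carbon. In this assay compound 2 reaches only a limit of the assay, > 20000 nM. The step is an at least 3.8-fold higher number from compound 1 to compound 2 (0.58 log units; beyond the scatter). Compound 3 `COc1nc(N)nc2c1c(-c1ccsc1)cn2[C@@H]1O[C@H](CO)[C@@H](O)[C@H]1O` carries amino in place of hydrogen on an aromatic carbon. In this assay compound 3 also stops at a limit of the assay, > 100000 nM. The step is an at least 19-fold higher number from compound 1 to compound 3 (1.28 log units; beyond the scatter). Compound 4 `COc1ncnc2c1c(-c1ccccc1)cn2[C@@H]1O[C@H](CO)[C@@H](O)[C@H]1O` differs from compound 1 at another position of the shared core: phenyl in place of thiophen-3-yl on an aromatic carbon. Among the measured compounds shown here, neither measured step touches this part of the molecule, and no measured pair separates the two aryl groups, so neither step offers a direct guide to this change. For the measured compounds named here, with no bearing step, compound 4 is expected to stay within the scatter of compound 1, a 1.1-fold higher number from compound 1 to compound 4 (0.03 log units; within the scatter). In this assay compound 4 is therefore estimated at 5500 nM, with a range from 1800 nM to 20000 nM.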

Compound 4, half-maximal inhibitory concentration: > 20000 nM
Compound 4: no number, only a limit; the forecaster's own chance of this, stated with the estimate: 20%; middle value at least 3.6-fold (0.56 log units) away from the limit.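

Among the compounds shown here, the position on the aromatic carbon two ring bonds from the ring nitrogen, untouched by the earlier steps, proves sensitive to the choice of aryl group: in this assay the step is an at least 3.8-fold higher number from compound 1 to compound 4 (0.58 log units; beyond the scatter). Until now, only changes elsewhere on the shared core had moved the number beyond the scatter, and this step shows that swapping one aromatic ring for another at this position can do so too. Compound 4 stops at a limit of the assay and not at a number, and the step has no upper end: the limit of > 20000 nM in this assay, at which 2 of the 4 values shown sit.

The compounds shown do not separate the loss of sulfur from the change to a six-membered ring. On these data alone, whether furan-3-yl, thiophen-2-yl, pyridin-3-yl or a small methyl group here would hold the number of compound 1 stays open.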